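The source may report more compounds than this note shows. Statements on the series, on what has been measured and on what is new or still open speak of the compounds shown alone.

Measured compounds

compound 1, `C#CCN1CCC(OC(=O)Nc2ccccc2)CC1`: in an assay on BTI-TN-5B1-4 cells for inhibition of Amine oxidase [flavin-containing] A (Homo sapiens), read by fluorescence and Amplex Red, using microsomes, with a stated time of 15 min (on this read-out higher numbers stand for weaker inhibition and lower numbers for stronger inhibition), compound 1 gives > 100000 nM, which is a limit of the assay and not a number.
compound 2, `O=C(Nc1ccccc1)OC1CCN(Cc2ccccc2)CC1`: in this assay compound 2 gives > 100000 nM, again a limit of the assay and not a number.

For the measured compounds named here, compound 1 therefore stands only at a limit; nothing places it more closely, and the one further value is also a limit (the limit of > 100000 nM in this assay, at which 2 of the 2 values shown sit). Going by the values given here, the single measured step, a step that the two limits leave unreadable from compound 1 to compound 2, is left unreadable by the two limits, so no size can be assigned to it.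

Compound 3, `C#CCN1CCC(OC(=O)Nc2ccc(C(C)C)cc2)CC1`, differs from compound 1 by isopropyl in place of hydrogen on an aromatic carbon on the shared core. Among the compounds with values here, no measured step touches this position or this kind of exchange, and the one step that exists cannot be read, so there is no ground for expecting a shift in this assay in either direction beyond the scatter. The step from compound 1 to compound 3 is therefore expected to be a step that the limit leaves unreadable from compound 1 to compound 3, meaning no readable change. Compound 3 is estimated at 150000 nM, with a range of 30000 nM to 600000 nM, and most likely the assay again reports only a limit.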

Compound 3, half-maximal inhibitory concentration: > 100000 nM
Compound 3: only a limit was reported; the forecaster's own chance of this, stated with the estimate: 85%; the middle value lies beyond the limit too.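

No new step can be read: compound 1 and compound 3 both stand only at a limit in this assay, and so does compound 2: the limit of > 100000 nM in this assay, at which 3 of the 3 values shown sit.

Whether isopropyl in place of hydrogen on an aromatic carbon changes inhibition at all stays open, as does how far beyond the limit any of these compounds lies.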